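Compound 3 to Compound 4: An Unsubstituted Amine Returns

The source may report more compounds than this note shows. Statements on the series, on what has been measured and on what is new or still open speak of the compounds shown alone.

In an ADME assay on HEp-2 cells (Homo sapiens) for cytotoxicity (on this read-out higher numbers stand for lower toxicity in this test and lower numbers for higher toxicity in this test), compound 3 `CC(C)CCn1c(Cn2c(=O)n(C(C)C)c3ccccc32)nc2cc(CNS(C)(=O)=O)ccc21` gives 30800 nM, at the upper end of the series alongside compound 2 `CC(C)CCn1c(Cn2c(=O)n(C(C)C)c3ccccc32)nc2cc(CNC3CC3)ccc21` at 17200 nM. The step between these two, a 1.8-fold higher number from compound 2 to compound 3 (0.25 log units; within the scatter), does not separate them. Compound 1 `CC(C)CCn1c(Cn2c(=O)n(C(C)C)c3ccccc32)nc2cc(CN)ccc21` stands lowest at 3920 nM.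

Compound 4 `CC(C)CCn1c(Cn2c(=O)n(C(C)C)c3ccccc32)nc2cc(C(C)(C)N)ccc21` follows from 1-amino-1-methylethyl in place of (methanesulfonamido)methyl on an aromatic carbon. The measured steps that bear on this change are the two that put a group on a bare amine nitrogen, a 7.9-fold higher number from compound 1 to compound 3 (0.90 log units; beyond the scatter) and a 4.4-fold higher number from compound 1 to compound 2 (0.64 log units; beyond the scatter). Both are modest and beyond the scatter. Compound 4 again has no such group on its amine nitrogen, and most of the first step is therefore expected to reverse, although no measurement tests the two-methyl carbon that carries this amine. The expected step, toward a lower number and of modest size, is a 5.1-fold lower number from compound 3 to compound 4 (0.71 log units; beyond the scatter). For compound 4 the estimated value is 6000 nM, with an expected range of 2000 nM to 18000 nM.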

Compound 4, half-maximal cytotoxic concentration: 3270 nM
Compound 4: middle estimate off by 1.8-fold (0.26 log units), on the high side; the measured number falls inside the stated range.
By their numbers in this assay, from the lowest: compounds 4 and 1 (each within the scatter of the next); then compounds 2 and 3 (each within the scatter of the next).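

Aminomethyl and 1-amino-1-methylethyl are not separated in this assay (a 1.2-fold lower number from compound 1 to compound 4 (0.08 log units; within the scatter)), so the two added methyl groups on the carbon carrying the amine leave no readable mark on this number. The (methanesulfonamido)methyl and (cyclopropylamino)methyl compounds both stand apart from the new compound (a 9.4-fold lower number from compound 3 to compound 4 (0.97 log units; beyond the scatter); a 5.3-fold lower number from compound 2 to compound 4 (0.72 log units; beyond the scatter)), which extends the earlier split to all four compounds: both with an unsubstituted amine nitrogen stand low, both with a substituted one stand high, and none goes against this. Nothing available explains these steps.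

Still open, going by these compounds, is whether methylsulfonyl or cyclopropyl on the nitrogen of 1-amino-1-methylethyl would give the same higher number as on aminomethyl. Also open, on these data alone, is where 1-aminoethyl, 1-aminocyclopropyl or hydroxymethyl would fall at this position.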